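Pyrazine in Place of Pyridine on the Piperazine Nitrogen

This account rests on a few compounds, and the source may have more. Where it says the series, first, only, none or still open, it means among the compounds named here.

Measured so far:
Compound 1, `Nc1ccccc1NC(=O)c1ccc(CSC(=S)N2CCN(Cc3ccncc3)CC2)cc1`, gives 79.3% in a functional assay on MGC-803 cells (Homo sapiens) for antiproliferative activity, read by CCK-8 assay, with a stated time of 72 h, tested at 8 uM; on this read-out higher numbers stand for a stronger effect at the one concentration tested and lower numbers for a weaker effect.
Compound 2, `Nc1ccccc1NC(=O)c1ccc(CSC(=S)N2CCN(c3ccccc3F)CC2)cc1`, gives 86.4%.
Compound 3, `Nc1ccccc1NC(=O)c1ccc(CSC(=S)N2CCN(c3ccncc3)CC2)cc1`, gives 87.1%.

Compound 3 holds the highest of the three numbers, but the gap from compound 2 is a number 0.7 percentage points higher from compound 2 to compound 3 (within the scatter) and the gap from compound 1 is a number 7.8 percentage points higher from compound 1 to compound 3 (within the scatter), so the three compounds cannot be told apart on these data. The three share one core and differ only in the group on an amine nitrogen in a ring.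

Compound 4, `Nc1ccccc1NC(=O)c1ccc(CSC(=S)N2CCN(c3cnccn3)CC2)cc1`, has not yet been tested. It differs from compound 3 in one place: pyrazin-2-yl in place of pyridin-4-yl on an amine nitrogen in a ring.

Among the measured compounds shown here, the steps that bear on this change are those that swap the group at the same position. The step of a number 7.1 percentage points higher from compound 1 to compound 2 (within the scatter), the step of a number 7.8 percentage points higher from compound 1 to compound 3 (within the scatter) and the step of a number 0.7 percentage points higher from compound 2 to compound 3 (within the scatter) all stay within the scatter, even where a ring is exchanged for another ring or a linker is removed. For the measured compounds named here, nothing among the measured compounds points to a step beyond the scatter for a further ring exchange at this position.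

For compound 4 the expected step is a number 2.1 percentage points lower from compound 3 to compound 4 (within the scatter), that is, none beyond the scatter. Compound 4 is therefore estimated at 85%, with a range from 72% to 94%.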

Compound 4, a percentage reported as inhibition, at one concentration (the size of the read-out at that concentration, not a potency): 80.5%
Compound 4: the middle estimate sits 4.5 percentage points above what was measured; the range from low to high includes it.
By their numbers in this assay, from the lowest: compounds 1, 4, 2 and 3 (each within the scatter of the next).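

In this assay, the pyrazin-2-yl group, a six-membered aromatic ring with 2 hetero atoms and 2 hydrogen-bond acceptors, can replace pyridin-4-yl on this amine nitrogen in a ring with a step that stays within the scatter (a number 6.6 percentage points lower from compound 3 to compound 4 (within the scatter)). Its steps from the two other groups are also within the scatter (a number 5.9 percentage points lower from compound 2 to compound 4 (within the scatter); a number 1.2 percentage points higher from compound 1 to compound 4 (within the scatter)), so the four groups at this position, now including a ring with a second hetero atom, cannot be told apart in this read-out. Nothing measured here gives a reason for these small differences.

From the compounds shown here alone, whether a group of another kind on this nitrogen, such as a simple amine on a longer chain or a carboxylic acid, would give a step beyond the scatter stays open. A reading at one concentration is also not a potency, so any differences in potency among these four compounds remain unresolved.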